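Fluoro to trifluoromethyl steps across two vinyl sulfide cores

The compounds below may be only part of what the source reports. "The series", "measured", "known", "first", "only" and "open" are said of these compounds alone.

Compound 1 `O=C(O)c1ccc(C(=O)/C(=C\c2ccc(Cl)c([N+](=O)[O-])c2)SCc2ccc(C(F)(F)F)cc2)cc1` and compound 2 `O=C(O)c1ccc(C(=O)/C(=C\c2ccc(Cl)c([N+](=O)[O-])c2)SCc2ccc(F)cc2)cc1` share one core; compound 3 `Cc1ccc(S/C(=C/c2ccc(F)cc2F)C(=O)c2ccc(Br)cc2)cc1` and compound 4 `Cc1ccc(S/C(=C/c2ccc(F)cc2C(F)(F)F)C(=O)c2ccc(Br)cc2)cc1` share another, and the difference between the two cores is not broken down here. In a functional assay on DU-145 cells (Homo sapiens) for inhibition, read by trypan blue exclusion, with a stated time of 96 h (on this read-out lower numbers stand for stronger inhibition of growth and higher numbers for weaker inhibition of growth), compound 1 gives 1000 nM and compound 2 gives 1000 nM. The change from compound 2 to compound 1 is trifluoromethyl in place of fluoro on an aromatic carbon, and no change at the digits printed from compound 2 to compound 1 (within the scatter). For compound 3 this assay reports only a limit, > 100000 nM, which sits at the limit of > 100000 nM in this assay, at which 1 of the 3 values shown sits. Compound 4 carries the same kind of change, (trifluoromethyl in place of fluoro on an aromatic carbon), though its place is ortho to a large group and meta to a fluoro group rather than para to a large group. The step from compound 3 to compound 4 is expected to be small, a step that the limit leaves unreadable from compound 3 to compound 4, because no change at the digits printed from compound 2 to compound 1 (within the scatter). Compound 4 is therefore expected to stay near the limit in this assay, estimated at 150000 nM, between 50000 nM and 500000 nM.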

Compound 4, concentration for 50% growth inhibition: 25000 nM
The estimate for compound 4 lay 6.0-fold (0.78 log units) above the measured number; measured number below the stated range.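

In this assay, replacing fluoro with trifluoromethyl on an aromatic carbon does not carry over as one fixed step from core to core: the same change on two cores in this assay, no change at the digits printed (within the scatter) from compound 2 to compound 1 and an at least 4.0-fold lower number (0.60 log units; beyond the scatter) from compound 3 to compound 4, at least 4.0-fold (0.60 log units) apart, beyond the scatter of two such steps

Read alone, an at least 4.0-fold lower number from compound 3 to compound 4 (0.60 log units; beyond the scatter) is a bound and not a measured size. Compound 3 has only a limit, > 100000 nM, and nothing shown separates the role of the core from that of the place on the ring.

Open, going by these compounds, is whether the lower number on the core of compound 4 also appears with a nitrile, a methoxy group or an amine in place of trifluoromethyl. Also open, on these data alone, is whether the same replacement at another place on the core of compound 1 would follow the step seen on the core of compound 4.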